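The source may hold more compounds than are shown below. What is called first, only, known or untested is meant among the compounds shown, and "the series" means these compounds.

Compound 1 `CN(C)CCNc1ccnc2cc(OCc3ccccc3)ccc12` gives 2350 nM in a functional assay on RKO cells (Homo sapiens) for cytotoxicity, read by MTT assay, with a stated time of 48 h; on this read-out lower numbers stand for stronger inhibition and higher numbers for weaker inhibition; compound 2 `C=CCOc1ccc2c(NCCN(C)C)ccnc2c1` gives 1270 nM; compound 3 `CCOc1ccc2c(Cl)ccnc2c1` gives 3870 nM.

Compound 3 stands highest of these three numbers in this assay. Compound 1 is its nearest neighbour, with a value that lies within the scatter of compound 3's; compound 2 lies furthest away, with a lower number that falls beyond the scatter.

Compound 4 `CCOc1ccc2c(NCCN(C)C)ccnc2c1` differs from compound 3 by (2-(dimethylamino)ethyl)amino in place of chloro on an aromatic carbon. Going by the values given here, the only measured step, a 1.9-fold lower number from compound 1 to compound 2 (0.27 log units; within the scatter), alters the group on the ether oxygen and not the position that changes here, so it does not bear directly on this replacement; it only shows how small a shift that other change made. What the measured set does show is that compound 1 and compound 2, both carrying the entering group, give the two lower numbers, while compound 3, carrying chloro, gives the highest. On that basis compound 4 is expected to give 1500 nM in this assay, with a likely range from 500 nM to 4500 nM. This amounts to an expected 2.6-fold lower number from compound 3 to compound 4 (0.41 log units; beyond the scatter), with the caveat that the direct comparison has not been measured.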

Compound 4, half-maximal inhibitory concentration: 3650 nM
Estimate against measurement, compound 4: 2.4-fold (0.39 log units) below; the measured number falls inside the stated range.
By their numbers in this assay, from the lowest: compounds 2, 1, 4 and 3 (each within the scatter of the next, the first and the last beyond it).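

In this assay, the direct replacement on this aromatic carbon, opposite the ring nitrogen, gives a 1.1-fold lower number from compound 3 to compound 4 (0.03 log units; within the scatter), so chloro and (2-(dimethylamino)ethyl)amino are not told apart here and the entering group alone does not account for the lower numbers of compound 1 and compound 2. With that group held in place, the change on the ether side gives a 2.9-fold higher number from compound 2 to compound 4 (0.46 log units; beyond the scatter), whereas the exchange of phenyl for methyl gives a 1.6-fold higher number from compound 1 to compound 4 (0.19 log units; within the scatter). No measurement shown here accounts for these results.

The compounds shown leave open whether chloro and (2-(dimethylamino)ethyl)amino would also stay level with vinyl or phenyl at the ether side. They also leave open how a morpholine ring or a longer chain between the two nitrogens would compare.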